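The source may hold more compounds than are shown below. What is called first, only, known or untested is meant among the compounds shown, and "the series" means these compounds.

Measured compounds:
compound 1 `O=C(Nc1cccc(-c2oc3cc(-c4ccc(F)cc4)ccc3c(=O)c2O)c1)c1ccc(F)cc1F` — 20500 nM
compound 2 `COc1ccccc1C(=O)Nc1cccc(-c2oc3cc(-c4ccc(F)cc4)ccc3c(=O)c2O)c1` — 11700 nM

In a functional assay on A549 cells (Homo sapiens) for antiproliferative activity, read by CCK-8 assay, with a stated time of 72 h (on this read-out higher numbers stand for weaker inhibition and lower numbers for stronger inhibition), compound 1 gives 20500 nM. In this assay compound 2 gives 11700 nM. Among the measured compounds shown here, the only step between measured compounds, 2-methoxyphenyl in place of 2,4-difluorophenyl on the carbonyl carbon, reads a 1.8-fold lower number from compound 1 to compound 2 (0.24 log units; within the scatter), so compound 2 and compound 1 stand within the scatter of each other and neither can be set apart from the other on these numbers.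

Compound 3 `O=C(Nc1cccc(-c2oc3cc(-c4ccc(F)cc4)ccc3c(=O)c2O)c1)c1ccc(C(F)(F)F)cc1` is not yet measured. Its change from compound 2 is 4-(trifluoromethyl)phenyl in place of 2-methoxyphenyl on a carbonyl carbon. For the measured compounds named here, no measured step carries a 4-(trifluoromethyl)phenyl group, so the one available comparison is the exchange of the aroyl group from compound 1 to compound 2, which stayed within the scatter. The two aroyl groups measured so far gave numbers close to each other, and nothing in the series shows this position moving the read-out strongly. For compound 3 the expected step is therefore a 1.3-fold higher number from compound 2 to compound 3 (0.11 log units; within the scatter), that is, no change beyond the scatter. Compound 3 is estimated at 15000 nM in this assay, with a range from 6000 nM to 40000 nM.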

Compound 3, half-maximal inhibitory concentration: 19400 nM
Beside the measured number, compound 3's estimate is 1.3-fold (0.11 log units) below it; the measured number falls inside the stated range.
By their numbers in this assay, from the lowest: compounds 2, 3 and 1 (each within the scatter of the next).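

In this assay, 4-(trifluoromethyl)phenyl on the carbonyl carbon whose other neighbour is the amide-type nitrogen gives a 1.7-fold higher number from compound 2 to compound 3 (0.22 log units; within the scatter) when it replaces 2-methoxyphenyl, and a 1.1-fold lower number from compound 1 to compound 3 (0.02 log units; within the scatter) when it replaces 2,4-difluorophenyl. Three aryl groups now stand at this position, and all three steps among them lie within the scatter, so neither the exchange of 2-methoxyphenyl, with its counted hydrogen-bond acceptor, nor the larger 4-(trifluoromethyl)phenyl group separates compound 3 from compound 1 or compound 2 on these numbers. Nothing available explains why these steps stay this small.

As far as these compounds go, whether this position can move the read-out at all stays open: a carboxylic acid or an aminomethyl group on the phenyl ring, or a piperidine in its place, would test that beyond this narrow set of substituted phenyl groups. The three compounds also share the rest of the structure unchanged, so what that part contributes to the read-out cannot be told from these numbers.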